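Chloro for bromo and the expected cytotoxicity of compound 4

A few compounds are considered here, and "the series" means these few. Any claim that something is new, unique, unknown or untested is made for them only; others in the source may bear on it.

Compound 1 `CC1(c2ccc(NC(c3ccc(Br)cc3)c3nnnn3C(C)(C)C)cc2)NC(=O)c2ccccc2N1` is tested in an ADME assay on J774.A1 cells (Mus musculus) for cytotoxicity, read by MTT assay, with a stated time of 72 h (on this read-out higher numbers stand for lower toxicity in this test and lower numbers for higher toxicity in this test), where compound 1 gives 400000 nM. Compound 2 `CC1(c2ccc(NC(c3ccc(Cl)cc3)c3nnnn3C(C)(C)C)cc2)NC(=O)c2ccccc2N1` differs from it by chloro in place of bromo on an aromatic carbon. In this assay compound 2 reaches only a limit of the test, > 400000 nM. The step of a number no lower from compound 1 to compound 2 (the limit leaves the size open) is shaped by the limit of > 400000 nM in this assay, at which 2 of the 3 values shown sit. Compound 3 `CC1(c2ccc(NC(c3ccc(Br)cc3)c3nnnn3C3CCCCC3)cc2)NC(=O)c2ccccc2N1` has a different core, and the difference between the two cores is cyclohexyl in place of tert-butyl on an aromatic nitrogen. In this assay compound 3 also reaches only a limit, > 400000 nM. The step of a number no lower from compound 1 to compound 3 (the limit leaves the size open) is likewise shaped by the limit of > 400000 nM in this assay, at which 2 of the 3 values shown sit. Compound 4 `CC1(c2ccc(NC(c3ccc(Cl)cc3)c3nnnn3C3CCCCC3)cc2)NC(=O)c2ccccc2N1` differs from compound 3 by chloro in place of bromo on an aromatic carbon, the same change as from compound 1 to compound 2. For compound 4 the expected step is a number no higher from compound 3 to compound 4 (the limit leaves the size open), resting on compound 3 with > 400000 nM. Compound 2 with > 400000 nM supports the same expectation. Compound 4 is therefore estimated at 400000 nM, between 200000 nM and 800000 nM, and a limit is again likely.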

Compound 4, half-maximal cytotoxic concentration: > 400000 nM
Compound 4 gave a limit, no number (the forecaster's own chance of this, stated with the estimate: 70%); the middle value sits exactly at the limit.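

Among the compounds shown here, no step from compound 2 or compound 3 to compound 4 can be read in this assay, because all three values are limits: the limit of > 400000 nM in this assay, at which 3 of the 4 values shown sit. The compounds shown leave open how compound 2, compound 3 and compound 4 rank against one another.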